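Notes on the step from compound 3 to compound 4

The compounds below may be only part of what the source reports. "The series", "measured", "known", "first", "only" and "open" are said of these compounds alone.

Values in a physicochemical assay for solubility, in simulated intestinal fluid; on this read-out lower numbers stand for lower solubility and higher numbers for higher solubility:
- Compound 1 `C[C@@H]1CN(c2sc(C(F)(F)F)nc2-c2nc3ccccc3[nH]2)CCN1C(=O)Cn1cccn1`: 734 ug/mL
- Compound 2 `Cc1nc(C)n(CC(=O)N2CCN(c3sc(C(F)(F)F)nc3-c3nc4ccccc4[nH]3)C[C@H]2C)n1`: > 850 ug/mL (a limit of the assay, not a number)
- Compound 3 `C[C@@H]1CN(c2sc(C(F)(F)F)nc2-c2nc3ccccc3[nH]2)CCN1C(=O)Cn1cnc2cccnc21`: 214 ug/mL

Compound 3, at 214 ug/mL, has the lower of the two actual numbers, and compound 1 is the nearest to it. The change to compound 4 `C[C@@H]1CN(c2sc(C(F)(F)F)nc2-c2nc3cc(OCCO)ccc3[nH]2)CCN1C(=O)Cn1cnc2cccnc21` is 2-hydroxyethoxy in place of hydrogen on an aromatic carbon. The measured steps lie elsewhere, on a saturated chain carbon bound to a carbonyl carbon: a 3.4-fold lower number from compound 1 to compound 3 (0.54 log units; beyond the scatter) and an at least 3.9-fold lower number from compound 2 to compound 3 (0.59 log units; beyond the scatter). They bear on this change only indirectly, as a gauge of how far this assay has moved within the series. Neither involves the entering group, so no step beyond the scatter is expected, and the direction stays uncertain. The expected result is a 1.2-fold higher number from compound 3 to compound 4 (0.08 log units; within the scatter). For compound 4 the estimated value is 260 ug/mL, with an expected range of 90 ug/mL to 750 ug/mL.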

Compound 4, solubility: 549 ug/mL
Beside the measured number, compound 4's estimate is 2.1-fold (0.32 log units) below it; the measured number falls inside the stated range.
By their numbers in this assay, from the lowest: compound 3; then compounds 4 and 1 (each within the scatter of the next). At a limit, above all of these: compound 2.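

In this assay, 2-hydroxyethoxy in place of hydrogen on an aromatic carbon of the six-membered ring of carbon only gives a 2.6-fold higher number from compound 3 to compound 4 (0.41 log units; beyond the scatter). Among the compounds shown here, the earlier steps all lay on the saturated chain carbon bound to a carbonyl carbon, so this is the first sign that a change on this ring also moves the number by a step beyond the scatter. Compound 2 stands at a limit, not a number, and compound 4 does not: the limit of > 850 ug/mL in this assay, at which 1 of the 4 values shown sits.

From the compounds shown here alone, whether the step belongs to the whole 2-hydroxyethoxy group or to its terminal hydroxyl stays open, and a methoxy group, an amine or a longer chain at this place would bear on that. Also open, going by these compounds, is whether the same change gives a similar step with the pyrazolyl group of compound 1.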